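Chloro to methyl: a step with one precedent

A few compounds are considered here, and "the series" means these few. Any claim that something is new, unique, unknown or untested is made for them only; others in the source may bear on it.

Of the compounds shown here, two carry numbers so far in a functional assay on the whole organism with Mus musculus as the target; a lower number here means that less compound is needed, a higher number that more compound is needed for the effect. Compound 1 `CN1C(=O)CCC1(O)c1cccc(C(F)(F)F)c1` gives 129 mg/kg, and compound 2 `CN1C(=O)CCC1(O)c1cccc(Cl)c1` gives 186 mg/kg. Compound 2 therefore stands level with compound 1, as the gap between them lies within the scatter.

The next member, compound 3 `Cc1cccc(C2(O)CCC(=O)N2C)c1`, keeps the shared core and differs from compound 2 at one place, with methyl in place of chloro on an aromatic carbon. For the measured compounds named here, no measured step involves methyl, so the evidence is indirect. Going by the values given here, the one step that bears on this change is a 1.4-fold higher number from compound 1 to compound 2 (0.16 log units; within the scatter), where chloro replaces trifluoromethyl on an aromatic carbon. Among the compounds with values here, that exchange at the same place stays within the scatter, and it is the only such exchange measured, so the basis is thin. No shift beyond the scatter is therefore expected in this assay, and no direction is favoured.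

The expected change is a 1.1-fold lower number from compound 2 to compound 3 (0.04 log units; within the scatter), which is a step within the scatter. For compound 3 the estimated value is 170 mg/kg, with an expected range of 85 mg/kg to 340 mg/kg.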

Compound 3, dose for half-maximal effect: 93 mg/kg
For compound 3 the middle estimate is 1.8-fold (0.26 log units) above the measured one; measured number inside the range.
By their numbers in this assay, from the lowest: compounds 3, 1 and 2 (each within the scatter of the next).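

Working notes on the aromatic position: with methyl in place of chloro, this assay gives a step at the limit of what still counts as scatter (a 2.0-fold lower number from compound 2 to compound 3 (0.30 log units; within the scatter)), the largest step in the series so far but not one that separates the two compounds. Methyl in place of trifluoromethyl, a second exchange at the same carbon, gives a 1.4-fold lower number from compound 1 to compound 3 (0.14 log units; within the scatter), so methyl, chloro and trifluoromethyl all lie within the scatter of one another and this carbon now has three substituents that this whole-organism read-out does not tell apart. No supporting measurement is available to explain why these three groups read alike.

The compounds shown leave open whether a group of a different kind at this carbon, such as an amine, a carboxylic acid or a longer chain, would give a step beyond the scatter. They also leave open whether methyl, chloro or trifluoromethyl would read alike on another carbon of the ring, and whether changes to the shared core would matter more than changes at this position.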